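This account rests on a few compounds, and the source may have more. Where it says the series, first, only, none or still open, it means among the compounds named here.

Compound 2 is `O=C(OC1CCC(CN2CCN(c3cc(=O)c4cc(C(F)(F)F)cc([N+](=O)[O-])c4s3)CC2)CC1)c1ccncc1`. In an ADME assay on Vero cells (Chlorocebus sabaeus) for cytotoxicity, read by MTT assay, with a stated time of 48 h (a lower number here means a stronger inhibitor, a higher number a weaker inhibitor), compound 2 gives > 64 ug/mL, which is a limit of the assay rather than a number. Among the compounds with values here, compound 1, `O=c1cc(N2CCN(CC3CCC(OS(=O)(=O)c4cccnc4)CC3)CC2)sc2c([N+](=O)[O-])cc(C(F)(F)F)cc12`, is the only other compound measured here. In this assay compound 1 gives > 64 ug/mL, again a limit. The step that the two limits leave unreadable from compound 1 to compound 2 therefore cannot be read, and all that the two measurements show is the limit of > 64 ug/mL in this assay, at which 2 of the 2 values shown sit. Compound 3 is `O=C(OC1CCC(CN2CCN(c3cc(=O)c4cc(C(F)(F)F)cc([N+](=O)[O-])c4s3)CC2)CC1)c1ccc(F)cc1`. It differs from compound 2 by 4-fluorophenyl in place of pyridin-4-yl on a carbonyl carbon. Within the data shown here, since the single step between measured compounds is unreadable, no measured step bears on this change, and the expectation rests only on compound 2 standing at the limit > 64 ug/mL. The expected step that the limit leaves unreadable from compound 2 to compound 3 is small, within the usual scatter. Compound 3 is therefore expected to give 80 ug/mL, in a range from 30 ug/mL to 200 ug/mL.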

Compound 3, half-maximal inhibitory concentration: > 64 ug/mL
Compound 3 ended at the assay's limit; the forecaster's own chance of this, stated with the estimate: 75%; the middle value is on the limit's open side.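

The steps among compound 1, compound 2 and compound 3 cannot be read, since each value is a limit and not a number: the limit of > 64 ug/mL in this assay, at which 3 of the 3 values shown sit.

The compounds shown leave open what actual value each one has in this assay, and so whether swapping these groups changes it at all.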